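This account rests on a few compounds, and the source may have more. Where it says the series, first, only, none or still open, it means among the compounds named here.

Measured compounds in a functional assay on SNB-75 cells (Homo sapiens) for inhibition; on this read-out lower numbers stand for stronger inhibition of growth and higher numbers for weaker inhibition of growth:
- compound 1 `COc1cc(/C=C/C(=O)c2cccc(-n3cc(-c4ccc(Cl)cc4)[nH]c3=O)c2)ccc1O` gives 2750 nM
- compound 2 `COc1cc(/C=C/C(=O)c2cccc(-n3cc(-c4ccccc4)[nH]c3=O)c2)cc(OC)c1OC` gives 4470 nM
- compound 3 `COc1cc(/C=C/C(=O)c2cccc(-n3cc(-c4ccccc4)[nH]c3=O)c2)ccc1O` gives 3900 nM

Compound 1 carries the smallest of the three numbers, yet its gaps to compound 3 and to compound 2 both lie within the usual scatter. Among the compounds with values here, the one measured step, a 1.4-fold higher number from compound 1 to compound 3 (0.15 log units; within the scatter), concerns a different part of the molecule and stayed within scatter. Compound 4 `O=C(/C=C/c1cccc(O)c1)c1cccc(-n2cc(-c3ccc(Cl)cc3)[nH]c2=O)c1` differs from compound 1 by 3-hydroxyphenyl in place of 4-hydroxy-3-methoxyphenyl on a double-bonded chain carbon bound to a double-bonded chain carbon. Within the data shown here, no measured step touches this group, so nothing argues for a shift beyond the scatter in either direction, but the uncertainty is wide. Compound 4 is therefore expected at about 3000 nM, with a range from 1200 nM to 8000 nM, which means an estimated step of a 1.1-fold higher number from compound 1 to compound 4 (0.04 log units; within the scatter).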

Compound 4, concentration for 50% growth inhibition: 1460 nM
Estimate against measurement, compound 4: 2.1-fold (0.31 log units) above; measured number inside the range.
By their numbers in this assay, from the lowest: compounds 4, 1, 3 and 2 (each within the scatter of the next, the first and the last beyond it).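

Within the data shown here, the first look at this group comes from replacing 4-hydroxy-3-methoxyphenyl with 3-hydroxyphenyl on the double-bonded chain carbon, which in this assay gives a 1.9-fold lower number from compound 1 to compound 4 (0.27 log units; within the scatter). This position therefore accepts a group with one heavy-atom-lighter substitution pattern, losing the methoxy and keeping a single hydroxy on another ring carbon, without a shift beyond the scatter. Nothing measured here offers an explanation for this result.

Still open, on these data alone, is how an amine or a carboxylic acid on this phenyl ring would read. Also open, as far as these compounds go, is whether the same swap would behave alike on the core of compound 3.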